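The source may report more compounds than this note shows. Statements on the series, on what has been measured and on what is new or still open speak of the compounds shown alone.

- compound 1 `OCCCCCC(O)c1ccc(-c2ccc(Br)cc2)cc1`: 20000 nM
- compound 2 `OCCCCCC(O)c1ccc(-c2ccc(F)cc2)cc1`: 18000 nM
- compound 3 `OCCCCCC(O)c1ccc(-c2ccc(C(F)(F)F)cc2)cc1`: 13000 nM

These three values all come from a functional assay on J774 cells (Mus musculus) for cytotoxicity, read by resazurin assay; on this read-out higher numbers stand for weaker inhibition and lower numbers for stronger inhibition. In this series, compound 3 gives 13000 nM, which cannot be told apart from the other two values, since its gaps to both lie within the usual scatter of repeated measurements.

The next compound is compound 4 `CCOc1ccc(-c2ccc(C(O)CCCCCO)cc2)cc1`, which has ethoxy in place of trifluoromethyl on an aromatic carbon. The rest of the molecule stays the same.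

The measured steps that bear on this change are the swaps of one group for another at this same place. They are a 1.1-fold lower number from compound 1 to compound 2 (0.05 log units; within the scatter), a 1.5-fold lower number from compound 1 to compound 3 (0.19 log units; within the scatter) and a 1.4-fold lower number from compound 2 to compound 3 (0.14 log units; within the scatter). All three are small and within the scatter, so bromo, fluoro and trifluoromethyl have made no clear difference here. Among the measured compounds shown here, no measured compound carries ethoxy, however, so this is an extrapolation to a new kind of group, and the range should stay fairly wide.

No clear move in either direction is therefore expected in this assay. The expected change is a 1.2-fold higher number from compound 3 to compound 4 (0.06 log units; within the scatter), which would not go beyond the scatter. For compound 4 the estimated value is 15000 nM, with an expected range from 8000 nM to 26000 nM.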

Compound 4, half-maximal inhibitory concentration: 14000 nM
Estimate against measurement, compound 4: 1.1-fold (0.03 log units) above, within the range that was stated.
By their numbers in this assay, from the lowest: compounds 3, 4, 2 and 1 (each within the scatter of the next).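

In this assay, among the compounds shown here, ethoxy is the first group at this place that counts as a hydrogen-bond acceptor, and it gives a 1.1-fold higher number from compound 3 to compound 4 (0.03 log units; within the scatter), a 1.3-fold lower number from compound 2 to compound 4 (0.11 log units; within the scatter) and a 1.4-fold lower number from compound 1 to compound 4 (0.15 log units; within the scatter). The earlier compounds shown here compared only bromo, fluoro and trifluoromethyl, whereas this result extends the flat picture to a group that enters through an oxygen atom: on this aromatic carbon, para to a large group, all four groups now give values that cannot be told apart, and none of the four compounds goes against this. Nothing measured alongside these compounds offers an explanation for this flat result.

The compounds shown leave open whether an amine, a carboxylic acid or a longer chain such as butoxy at this same place would also stay within the scatter of these four, or would finally move the number in this assay. They also leave open whether altering the hydroxyl-bearing chain of the shared core, for instance by replacing a hydroxyl with an amine, would matter more than the group at this position.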